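This account rests on a few compounds, and the source may have more. Where it says the series, first, only, none or still open, it means among the compounds named here.

So far only two numbers exist in a functional assay on HeLa cells (Homo sapiens) for cytotoxicity, read by MTT assay (a lower number here means a stronger inhibitor, a higher number a weaker inhibitor), for this series: compound 1 (`COCCO[C@H](CC=C(C)C)C1=CC(=O)c2c(O)ccc(O)c2C1=O`) gives 62400 nM and compound 2 (`CCCC(CC(=O)O[C@H](CC=C(C)C)C1=CC(=O)c2c(O)ccc(O)c2C1=O)OC(C)=O`) gives 51200 nM on the same scale. These two values lie within the usual scatter of each other, so compound 2 stands level with compound 1 and neither can be called the stronger inhibitor. Compound 3 (`CC(C)=CC[C@@H](OC(=O)C1CCOC1)C1=CC(=O)c2c(O)ccc(O)c2C1=O`) has not yet been measured. Compared with compound 2, it carries oxolan-3-yl in place of 2-acetoxypentyl on a carbonyl carbon, which brings in one five-membered non-aromatic ring. Among the compounds with values here, no pair of measured compounds shows what this exchange does in this assay and the size of the step cannot be read directly from the data. Within the data shown here, the only guide is that compound 1 at 62400 nM and compound 2 at 51200 nM sit within the scatter of each other. On that slim basis, no step beyond the scatter is expected in either direction. The expected step is a 1.0-fold lower number from compound 2 to compound 3 (0.01 log units; within the scatter) as a rough estimate. Compound 3 is estimated at 50000 nM with an expected range from 20000 nM to 100000 nM in this assay.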

Compound 3, half-maximal inhibitory concentration: 73500 nM
Beside the measured number, compound 3's estimate is 1.5-fold (0.17 log units) below it, and the stated range covers the measured number.
By their numbers in this assay, from the lowest: compounds 2, 1 and 3 (each within the scatter of the next).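

In this assay, within the data shown here, the first measured exchange at this position puts oxolan-3-yl in place of 2-acetoxypentyl on a carbonyl carbon and gives a 1.4-fold higher number from compound 2 to compound 3 (0.16 log units; within the scatter), so the two compounds stand level even though a ring replaces an open chain and the group loses heavy atoms. A second comparison makes a larger exchange, with (oxolan-3-yl)carbonyl in place of 2-methoxyethyl on an oxygen on a saturated carbon, and gives a 1.2-fold higher number from compound 1 to compound 3 (0.07 log units; within the scatter), which again leaves the two compounds level. All three compounds therefore sit within the scatter of one another in this assay, and no measurement available here explains why these different groups give such similar numbers.

As far as these compounds go, these three groups carry no charge, so it remains open whether an amine or a carboxylic acid at this position would move the number beyond the scatter. It is equally unknown whether a much longer chain or an aromatic ring such as phenyl would do so, or whether this position can change the number at all.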